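This account rests on a few compounds, and the source may have more. Where it says the series, first, only, none or still open, it means among the compounds named here.

Compound 1, `COc1cc2c(=O)c(C(=O)c3ccc(C)cc3)cn(Cc3ccc(C(C)C)cc3)c2cc1OC`: 15500 nM
Compound 2, `COc1cc2c(=O)c(C(=O)c3ccc(C)cc3)cn(Cc3ccc(C(F)(F)F)cc3F)c2cc1OC`: > 25000 nM
Compound 3, `COc1cc2c(=O)c(C(=O)OCc3ccc(C)cc3)cn(Cc3ccc(C(F)(F)F)cc3F)c2cc1OC`: 20000 nM

In an ADME assay on Huh-7 cells (Homo sapiens) for cytotoxicity (a lower number here means a stronger inhibitor of growth, a higher number a weaker inhibitor of growth), compound 1 gives 15500 nM and compound 3 gives 20000 nM. For compound 2 this assay reports only a limit, > 25000 nM, so compound 2 stands at the limit of > 25000 nM in this assay, at which 1 of the 3 values shown sits, and has no number of its own. The measured steps are small: an at least 1.6-fold higher number from compound 1 to compound 2 (0.20 log units; that floor lies within the scatter) and an at least 1.2-fold lower number from compound 2 to compound 3 (0.09 log units; that floor lies within the scatter), both at floors that lie within the scatter.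

Compound 4, `COc1cc2c(=O)c(C(=O)c3ccc(C)cc3)cn(Cc3ccc(C(C)(C)C)cc3)c2cc1OC`, differs from compound 2 in one place: 4-(tert-butyl)phenyl in place of 2-fluoro-4-(trifluoromethyl)phenyl on a saturated chain carbon bound to an aromatic nitrogen. The step from compound 1 to compound 2 is the one that bears on it, since it runs the other way at the same place, and the group that enters in compound 4 stands close to the 4-isopropylphenyl of compound 1. Compound 4 is therefore expected to return toward the number of compound 1, a step of an at least 1.6-fold lower number from compound 2 to compound 4 (0.22 log units; that floor lies within the scatter) in this assay, meaning a lower number, though the floor of that step lies within the scatter. The estimate for compound 4 is 15000 nM, with a range from 7000 nM to 30000 nM.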

Compound 4, concentration for 50% growth inhibition: > 25000 nM
Compound 4 ended at the assay's limit; the forecaster's own chance of this, stated with the estimate: 25%; middle value at least 1.6-fold (0.22 log units) away from the limit.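

In this assay, compound 4 reports only a limit and no number of its own, as compound 2 does: the limit of > 25000 nM in this assay, at which 2 of the 4 values shown sit.

Going by these compounds alone, the step between these two compounds cannot be read, so exchanging 2-fluoro-4-(trifluoromethyl)phenyl for 4-(tert-butyl)phenyl on the saturated chain carbon bound to an aromatic nitrogen shows only that a group with fluorine and a group of carbon alone can both end at that limit. One added methyl, which turns the 4-isopropylphenyl of compound 1 into the 4-(tert-butyl)phenyl of compound 4, gives an at least 1.6-fold higher number from compound 1 to compound 4 (0.20 log units; that floor lies within the scatter), so this change is not shown to separate the two compounds.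

As far as these compounds go, how far compound 2 and compound 4 lie past the limit remains unknown. From the compounds shown here alone, it also remains open whether a group such as an amine or a carboxylic acid on this benzyl ring would give a step beyond the scatter.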